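The compounds below may be only part of what the source reports. "The series", "measured", "known", "first", "only" and "open" are said of these compounds alone.

In an ADME assay on HEK293 cells (Homo sapiens) for cytotoxicity, with a stated time of 72 h (a lower number here means that less compound is needed, a higher number that more compound is needed for the effect), compound 1 `COc1ccc(-c2nc3ccccc3o2)cc1NC(=O)c1cc([N+](=O)[O-])ccc1Cl` gives > 25000 nM as a limit of the assay and not a number. Compound 2 `Cc1cc(NC(=O)c2cc([N+](=O)[O-])ccc2Cl)cc(-c2nc3ccccc3o2)c1O` gives > 25000 nM as a limit too. Compound 3 `COc1ccc(-c2nc3ccccc3s2)cc1NC(=O)c1cc([N+](=O)[O-])ccc1Cl` gives > 25000 nM as a limit as well. Compound 1 therefore has no exact number to start from, and the measurements so far all rest on the limit of > 25000 nM in this assay, at which 3 of the 3 values shown sit, with no exception.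

Compound 4 `O=C(Nc1cc(-c2nc3ccccc3o2)ccc1F)c1cc([N+](=O)[O-])ccc1Cl` differs from compound 1 by fluoro in place of methoxy on an aromatic carbon in a single change: fluoro in place of methoxy on an aromatic carbon, para to a 1,3-benzoxazol-2-yl group. Going by the values given here, no measured step makes this exchange. Among the compounds with values here, the one measured step is a step that the two limits leave unreadable from compound 1 to compound 3 and it gives no size to carry over to the new change.

With only limits to go on, no step beyond the scatter is expected in this assay and the estimated step is a step that the limit leaves unreadable from compound 1 to compound 4 for this exchange. Compound 4 is estimated at 30000 nM within a range of 15000 nM to 60000 nM and is expected to be reported most likely as a limit again.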

Compound 4, half-maximal effective concentration: > 25000 nM
Compound 4 was reported as a limit; the forecaster's own chance of this, stated with the estimate: 85%; the middle value lies beyond the limit too.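

No step can be read between compound 1 and compound 4, as each result is a limit and not a number: the limit of > 25000 nM in this assay, at which 4 of the 4 values shown sit. The compounds shown leave open how much of any of them is needed for the effect in this assay, and whether exchanging methoxy for fluoro changes that amount.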